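This account rests on a few compounds, and the source may have more. Where it says the series, first, only, none or still open, it means among the compounds named here.

Working notes on the series. Of the compounds shown here, three of the shared core have been measured: compound 1 `N#Cc1ccc(C(=O)NC(=O)c2ccccc2O)cc1`, compound 2 `COc1cc(C(=O)NC(=O)c2ccccc2O)cc(OC)c1OC` and compound 3 `O=C(NC(=O)C1CCCCC1)c1ccccc1O`. In an ADME assay on L6 cells (Rattus norvegicus) for cytotoxicity, read by resazurin assay, with a stated time of 72 h (a higher number here means a weaker inhibitor, a lower number a stronger inhibitor), compound 1 gives 55 ug/mL, compound 3 gives 55 ug/mL and compound 2 gives 21 ug/mL. Compound 1 and compound 3 agree at the digits recorded and together hold the highest numbers of the three; the gap between them lies within the scatter, so no order between them is claimed. Among the measured compounds shown here, compound 2 stands furthest from compound 1, with a lower number that falls beyond the scatter, so it is the one compound of the three that reads as clearly more active in this assay than compound 1.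

The next compound, compound 4 `Nc1ccc(C(=O)NC(=O)c2ccccc2O)cc1`, follows from compound 1 by a single change: amino in place of cyano on an aromatic carbon. For the measured compounds named here, no measured pair shows this change, so its effect is unknown from the data. The expectation for compound 4 is a step of a 1.1-fold lower number from compound 1 to compound 4 (0.04 log units; within the scatter), that is no shift beyond the scatter, because compound 1 gives 55 ug/mL and compound 3, which carries a different partner on the same core, gives 55 ug/mL at the same digits. Compound 4 is accordingly estimated at 50 ug/mL, with a range of 25 ug/mL to 100 ug/mL.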

Compound 4, half-maximal inhibitory concentration: 39 ug/mL
Estimate against measurement, compound 4: 1.3-fold (0.11 log units) above; measured number inside the range.
By their numbers in this assay, from the lowest: compounds 2, 4, 1 and 3 (each within the scatter of the next, the first and the last beyond it).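

Amino in place of cyano on an aromatic carbon, para to a large group, now has a measured pair in this assay, and the record for it is a 1.4-fold lower number from compound 1 to compound 4 (0.15 log units; within the scatter). At this position the nitrile and the amine therefore read alike in this assay, although the exchange removes a triple bond and brings in a hydrogen-bond donor; this rests on a single pair and sets no trend for the series. No measurement at hand bears on this result, and none accounts for the step.

On these data alone, whether a carboxylic acid or a dimethylamino group at this same position would give a number beyond the scatter from compound 1 remains open. Also open, as far as these compounds go, is whether amino in place of cyano would give a step of this size on the shared core when other groups are present on the same ring.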